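From Cyclic Ether Amide to Carbamate: Estimating Compound 3

A few compounds are considered here, and "the series" means these few. Any claim that something is new, unique, unknown or untested is made for them only; others in the source may bear on it.

Compound 1 `Cc1cc(C(=O)Nc2cccc(F)c2)nn1Cc1cc(Cl)ccc1OCc1ccccc1`: 200 nM
Compound 2 `Cc1cc(NC(=O)C2CCOC2)nn1Cc1cc(Cl)ccc1OCc1ccccc1`: 39.8 nM

Going by the values given here, in an assay on CHO-K1 cells for displacement of a labelled ligand from prostaglandin E2 receptor EP1 subtype (Homo sapiens) (on this read-out lower numbers stand for stronger inhibition and higher numbers for weaker inhibition), compound 2 gives 39.8 nM, the lower of the two numbers measured so far; compound 1 gives 200 nM. Among the compounds with values here, the one measured step, a 5.0-fold lower number from compound 1 to compound 2 (0.70 log units; beyond the scatter), shows that changing the group on the amide side of the shared core can move the number by a modest amount.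

Compound 3 `Cc1cc(NC(=O)OCC(C)C)nn1Cc1cc(Cl)ccc1OCc1ccccc1` has not yet been measured. It differs from compound 2 by isobutoxy in place of oxolan-3-yl on a carbonyl carbon, so the amide of compound 2 becomes a carbamate. Within the data shown here, no measured step covers this exact change: the step from compound 1 to compound 2 swapped a fluorophenyl amide for the oxolane amide, not an oxolane for an isobutoxy. It tells only that this part of the molecule responds to change and that compound 2 sits at the better end.

Going by these compounds, because a 5.0-fold lower number from compound 1 to compound 2 (0.70 log units; beyond the scatter) shows a ring-free replacement is untested, compound 3 is expected to stay close to compound 2, within the scatter, with a 1.3-fold higher number from compound 2 to compound 3 (0.10 log units; within the scatter) as the estimated step. The expected value for compound 3 is 50 nM, within a range of 15 nM to 160 nM.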

Compound 3, half-maximal inhibitory concentration: 25.1 nM
Compound 3: middle estimate off by 2.0-fold (0.30 log units), on the high side, and the stated range covers the measured number.
By their numbers in this assay, from the lowest: compounds 3 and 2 (each within the scatter of the next); then compound 1.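

In this assay, the change to isobutoxy in place of oxolan-3-yl on a carbonyl carbon gives a 1.6-fold lower number from compound 2 to compound 3 (0.20 log units; within the scatter). The two groups match in their counts of heavy atoms and hydrogen-bond acceptors and differ in that oxolan-3-yl has a ring and isobutoxy has none, so among the compounds shown, the ring is not required for a number in this range, and an amide and a carbamate can read alike at this position. The measured gap to the fluorophenyl amide also remains clear, with an 8.0-fold lower number from compound 1 to compound 3 (0.90 log units; beyond the scatter), but nothing measured here explains either step.

The compounds shown leave open how far this agreement extends, such as whether a longer chain like hexyloxy or an amine like dimethylamino on the same carbonyl carbon would keep the number near those of compound 2 and compound 3. They also leave open whether the oxygen of isobutoxy matters, a question that an isobutyl group on that carbonyl carbon could address, since that group has the chain without the oxygen.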